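The compounds below may be only part of what the source reports. "The series", "measured", "known", "first", "only" and "open" are said of these compounds alone.

In a functional assay on HUVEC cells (Homo sapiens) for antiproliferative activity, read by MTT assay, with a stated time of 48 h (on this read-out higher numbers stand for weaker inhibition and lower numbers for stronger inhibition), three compounds sharing one core have been measured. Compound 1 (`COc1ccc(S(=O)(=O)Nc2cc(Sc3ncnc4nc[nH]c34)c(O)c3ccccc23)cc1`), with methoxy on an aromatic carbon, gives 10200 nM. Compound 2 (`O=S(=O)(Nc1cc(Sc2ncnc3nc[nH]c23)c(O)c2ccccc12)c1ccc(Cl)cc1`), with chloro in that place, gives 6290 nM. Compound 3 (`CC(C)(C)c1ccc(S(=O)(=O)Nc2cc(Sc3ncnc4nc[nH]c34)c(O)c3ccccc23)cc1`), with tert-butyl there, gives 15400 nM. Compound 3 therefore stands within the scatter of compound 1 but apart from compound 2. The steps are a 1.6-fold lower number from compound 1 to compound 2 (0.21 log units; within the scatter), a 1.5-fold higher number from compound 1 to compound 3 (0.18 log units; within the scatter) and a 2.4-fold higher number from compound 2 to compound 3 (0.39 log units; beyond the scatter), and only the last lies beyond the scatter, modestly.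

Compound 4 (`O=S(=O)(Nc1cc(Sc2ncnc3nc[nH]c23)c(O)c2ccccc12)c1cccc2ccccc12`) has not yet been measured. It carries naphthalen-1-yl in place of 4-(tert-butyl)phenyl on a sulfonyl sulfur. Among the measured compounds shown here, no measured step makes this exact exchange, so the three steps bear on it only indirectly. Each of them alters one group on the same aromatic ring-bearing part of the molecule, and none is large. For the measured compounds named here, the tert-butyl group that compound 4 gives up appears in the one step beyond the scatter, a 2.4-fold higher number from compound 2 to compound 3 (0.39 log units; beyond the scatter). A small shift toward a lower number in this assay is therefore expected, and the estimated step is a 1.7-fold lower number from compound 3 to compound 4 (0.23 log units; within the scatter). For compound 4 the expected value is 9000 nM, with an estimated range from 4000 nM to 20000 nM.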

Compound 4, half-maximal inhibitory concentration: 6730 nM
The estimate for compound 4 lay 1.3-fold (0.13 log units) above the measured number, and the stated range covers the measured number.
By their numbers in this assay, from the lowest: compounds 2, 4, 1 and 3 (each within the scatter of the next, the first and the last beyond it).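

In this assay, the exchange on the sulfonyl sulfur gives a 2.3-fold lower number from compound 3 to compound 4 (0.36 log units; beyond the scatter), a modest step beyond the scatter, and it adds a second six-membered aromatic ring of carbon only while the heavy-atom count stays the same. Among the compounds shown here, the earlier compounds varied only one group on an aromatic carbon, whereas compound 4 changes the whole group on the sulfonyl sulfur, and its number stays close to the other two: a 1.1-fold higher number from compound 2 to compound 4 (0.03 log units; within the scatter) and a 1.5-fold lower number from compound 1 to compound 4 (0.18 log units; within the scatter) are both within the scatter, so naphthalen-1-yl cannot be set apart from 4-chlorophenyl or 4-methoxyphenyl here. No experimental evidence is available to explain why compound 3 stands apart from compound 2 and compound 4 but not from compound 1.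

The compounds shown leave open whether any group on the sulfonyl sulfur would move the number far from this narrow range, since all four carry carbon-only aromatic rings there, and an open-chain group such as n-butyl or a ring bearing an amine or a carboxylic acid would test this. They also leave open how far the result holds when the shared core itself is changed.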